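The source may report more compounds than this note shows. Statements on the series, on what has been measured and on what is new or still open speak of the compounds shown alone.

Measured compounds:
compound 1 `COc1ccc(NC(=O)c2nc(-c3cc(OC)c(OC)c(OC)c3)n(-c3ccc(OC)cc3)n2)cc1`, 45%
compound 2 `COc1ccc(-n2nc(C(=O)Nc3ccccc3OC)nc2-c2cc(OC)c(OC)c(OC)c2)cc1`, 57%
compound 3 `COc1ccc(-n2nc(C(=O)Nc3ccc(C(F)(F)F)cc3)nc2-c2cc(OC)c(OC)c(OC)c2)cc1`, 55%

In a functional assay on the whole organism for inhibition, with Rattus norvegicus as the target, read by paw edema, with stated times of 30 min and 2 h, at a dose of 0.28 mmol/kg by the oral route (on this read-out higher numbers stand for more inhibition at the one dose given (going by the name of the read-out) and lower numbers for less inhibition), compound 2 gives 57%, the highest of the three numbers; its nearest neighbour is compound 3, and a number 2 percentage points lower from compound 2 to compound 3 (within the scatter), so the two cannot be ordered. The step of a number 12 percentage points higher from compound 1 to compound 2 (beyond the scatter) is the only one beyond the scatter, and a number 10 percentage points higher from compound 1 to compound 3 (within the scatter) stays inside it.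

Compound 4 `COc1ccc(-n2nc(C(=O)Nc3ccc(C(=O)O)cc3)nc2-c2cc(OC)c(OC)c(OC)c2)cc1` has not yet been measured. It differs from compound 2 in one place: 4-carboxyphenyl in place of 2-methoxyphenyl on an amide-type nitrogen. Among the compounds with values here, two measured steps bear on this, as both alter the group on the amide-type nitrogen: a number 12 percentage points higher from compound 1 to compound 2 (beyond the scatter) and a number 2 percentage points lower from compound 2 to compound 3 (within the scatter). Replacing 2-methoxyphenyl by another substituted phenyl on that nitrogen has so far moved the read-out by only a little, the larger step having been the one that introduced 2-methoxyphenyl. No measured compound carries a carboxyphenyl, so the direction of its effect is not shown by the data. Compound 4 is therefore expected to lie close to compound 2, with a small fall considered somewhat more likely than a rise: a number 7 percentage points lower from compound 2 to compound 4 (within the scatter). The estimate for compound 4 is 50%, within 35% to 65%.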

Compound 4, a percentage reported as inhibition, in the whole organism at one dose (the size of the read-out at that dose, not a potency): 57%
Compound 4: the middle estimate sits 7 percentage points below what was measured, within the range that was stated.
By their numbers in this assay, from the lowest: compounds 1, 3, 2 and 4 (each within the scatter of the next, the first and the last beyond it).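

In this assay, this amide-type nitrogen takes 4-carboxyphenyl in place of 2-methoxyphenyl with no change at the digits printed from compound 2 to compound 4 (within the scatter), and carboxy in place of trifluoromethyl on an aromatic carbon gives a number 2 percentage points higher from compound 3 to compound 4 (within the scatter), so a group bearing a hydrogen-bond donor reads the same here as the two groups without one. The third new step, a number 12 percentage points higher from compound 1 to compound 4 (beyond the scatter), gives a second group after 2-methoxyphenyl that stands apart from the 4-methoxyphenyl of compound 1 beyond the scatter, while compound 3 does not. Nothing given here bears on why these different groups read alike.

Open, as far as these compounds go, is whether an amine, a methyl ester or a longer chain ending in a carboxylic acid on this phenyl would keep the read-out. Also open, from the compounds shown here alone, is how these compounds would compare at other doses.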